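Adding a Third Methoxy to the Fluorinated Core

A few compounds are considered here, and "the series" means these few. Any claim that something is new, unique, unknown or untested is made for them only; others in the source may bear on it.

Three compounds have been characterised in an ADME assay on MDCK cells (Canis lupus familiaris) for cytotoxicity, read by MTT assay, with a stated time of 48 h; a lower number here means that less compound is tolerated, a higher number that more compound is tolerated. Compound 1 `COc1cc(OC)c([C@H]2CC(C)(O)[C@@H]3CC[C@@H](C)C[C@H]3O2)cc1OC` carries a hydroxyl on the shared core; in this assay compound 1 reaches only the limit of > 857000 nM, which is a limit and not a number. Compound 2 `COc1ccc([C@H]2CC(C)(F)[C@@H]3CC[C@@H](C)C[C@H]3O2)c(OC)c1` and compound 3 `COc1ccc(OC)c([C@H]2CC(C)(F)[C@@H]3CC[C@@H](C)C[C@H]3O2)c1` both carry fluorine in place of that hydroxyl and differ in where their two methoxy groups sit. In this assay compound 2 gives 379000 nM, while compound 3 gives 37000 nM, the lowest of the two numbers, below compound 2 in a gap that lies beyond the scatter.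

Compound 4 `COc1cc(OC)c([C@H]2CC(C)(F)[C@@H]3CC[C@@H](C)C[C@H]3O2)cc1OC` differs from compound 3 by methoxy in place of hydrogen on an aromatic carbon, ortho to a methoxy group and para to a large group. Among the measured compounds shown here, no measured step of this kind exists here. Given that compound 1, which shares this three-methoxy pattern, sits at the limit (the limit of > 857000 nM in this assay, at which 1 of the 3 values shown sits), compound 4 is expected to be tolerated at a higher concentration than compound 3, with a step of a 4.1-fold higher number from compound 3 to compound 4 (0.61 log units; beyond the scatter). Compound 4 is estimated at 150000 nM, between 30000 nM and 857000 nM.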

Compound 4, half-maximal cytotoxic concentration: 78000 nM
Estimate against measurement, compound 4: 1.9-fold (0.28 log units) above; the range from low to high includes it.
By their numbers in this assay, from the lowest: compound 3; then compound 4; then compound 2. At a limit, above all of these: compound 1.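

In this assay, methoxy in place of hydrogen on an aromatic carbon does not act in one direction: it gives a 2.1-fold higher number from compound 3 to compound 4 (0.32 log units; beyond the scatter), yet a 4.9-fold lower number from compound 2 to compound 4 (0.69 log units; beyond the scatter), so the outcome depends on which of the two methoxy patterns it completes. With the three-methoxy pattern held constant, fluoro in place of hydroxy on a saturated ring carbon can now be read on its own, as an at least 10-fold lower number from compound 1 to compound 4 (1.04 log units; beyond the scatter). That step has a limit at one end, since compound 1 carries a limit and not a number: the limit of > 857000 nM in this assay, at which 1 of the 4 values shown sits.

The compounds shown leave open whether an amine or a chloro group on the same aromatic carbon would follow the methoxy step. They also leave open whether the change from hydroxy to fluoro would read the same on the two-methoxy patterns of compound 2 and compound 3.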